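Methyl for cyclopropyl on the sulfonyl sulfur of compound 1

This account rests on a few compounds, and the source may have more. Where it says the series, first, only, none or still open, it means among the compounds named here.

Measured so far in an ADME assay for permeability, using PAMPA, at pH 7.4; on this read-out higher numbers stand for higher permeability and lower numbers for lower permeability
- compound 1 `CC(C)COc1ncc(-c2cn(C)c3cc(C(=O)NS(=O)(=O)C4CC4)c(F)cc23)cc1Cl` gives 310 nm/s
- compound 2 `CC(C)COc1ccc(-c2nn(C)c3cc(C(=O)NS(=O)(=O)C4CC4)c(F)cc23)cn1` gives 100 nm/s
- compound 3 `Cn1nc(-c2ccc(C(F)(F)F)cc2)c2cc(F)c(C(=O)NS(=O)(=O)C3CC3)cc21` gives 102 nm/s

Compound 1 stands highest of the three, and its gaps to compound 2 and to compound 3 both lie beyond the scatter. Compound 2 and compound 3 lie within the scatter of each other. The next compound to be read is compound 4 `CC(C)COc1ncc(-c2cn(C)c3cc(C(=O)NS(C)(=O)=O)c(F)cc23)cc1Cl` which differs from compound 1 by methyl in place of cyclopropyl on a sulfonyl sulfur and keeps the core of compound 1. Among the compounds with values here, no measured pair shows this change, so the expectation is loose. A small fall within the scatter is expected in this assay (a 1.5-fold lower number from compound 1 to compound 4 (0.17 log units; within the scatter)). Compound 4 is estimated at 210 nm/s with an expected range from 95 nm/s to 420 nm/s for the coming measurement.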

Compound 4, apparent permeability: 205 nm/s
Beside the measured number, compound 4's estimate is 1.0-fold (0.01 log units) above it, within the range that was stated.
By their numbers in this assay, from the lowest: compounds 2, 3, 4 and 1 (each within the scatter of the next, the first and the last beyond it).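

Methyl in place of cyclopropyl on a sulfonyl sulfur gives a 1.5-fold lower number from compound 1 to compound 4 (0.18 log units; within the scatter) in this assay and forms the first pair in the series that differs in one place. On the core of compound 1, this position therefore keeps its reading within the scatter when the three-membered ring is removed. Nothing available gives a reason for this step.

As far as these compounds go, whether a longer chain such as n-propyl, or an amine, on the sulfonyl sulfur reads alike remains open. So does whether the same change reads alike on the core of compound 2.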